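The source may hold more compounds than are shown below. What is called first, only, known or untested is meant among the compounds shown, and "the series" means these compounds.

Working notes on the series in a functional assay on OE19 cells (Homo sapiens) for cytotoxicity, read by MTT assay, with a stated time of 48 h; a higher number here means a weaker inhibitor, a lower number a stronger inhibitor. For the measured compounds named here, compound 1 `CC1(C)S[C@@H]2/C(=C\C(=O)c3ccc([N+](=O)[O-])cc3)C(=O)N2[C@H]1C(=O)OC(c1ccccc1)c1ccccc1` gives 44100 nM and stands lowest of the two numbers so far; its nearest neighbour, compound 2 `CC1(C)[C@H](C(=O)OC(c2ccccc2)c2ccccc2)N2C(=O)/C(=C/C(=O)c3ccc([N+](=O)[O-])cc3)[C@H]2S1(=O)=O`, gives 95500 nM, a difference beyond the scatter. Compound 3 `CC1(C)S[C@@H]2/C(=C\C(=O)c3ccccc3)C(=O)N2[C@H]1C(=O)OC(c1ccccc1)c1ccccc1` is not yet measured. It differs from compound 1 by hydrogen in place of nitro on an aromatic carbon. Going by the values given here, no measured pair covers this change, so the step from compound 1 is expected to be small, most likely toward a somewhat higher number, as a 1.6-fold higher number from compound 1 to compound 3 (0.20 log units; within the scatter). The estimate for compound 3 is 70000 nM, with a range from 25000 nM to 200000 nM.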

Compound 3, half-maximal inhibitory concentration: 12800 nM
Estimate against measurement, compound 3: 5.5-fold (0.74 log units) above; the whole stated range lies above it.
By their numbers in this assay, from the lowest: compound 3; then compound 1; then compound 2.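

In this assay, for the compounds shown here, the change from 4-nitrophenyl to phenyl gives a 3.4-fold lower number from compound 1 to compound 3 (0.54 log units; beyond the scatter) and this is the first reading at this position. The nitro is therefore not required for the cytotoxicity seen with the core of compound 1, and its removal gives a lower number by more than the usual scatter. No measurement at hand accounts for the step.

The compounds shown leave open how an amine, a methoxy group or a chlorine atom on the same aromatic carbon would read. Also open, as far as these compounds go, is whether the same change holds on the core of compound 2.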